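Thiophen-2-yl in place of 1H-pyrrol-2-yl on a carbonyl carbon

The source may hold more compounds than are shown below. What is called first, only, known or untested is meant among the compounds shown, and "the series" means these compounds.

In a functional assay on HCT-116 cells (Homo sapiens) for inhibition, read by sulforhodamine B assay, with a stated time of 3 days (a higher number here means a weaker inhibitor, a lower number a stronger inhibitor), compound 1 `O=C1Nc2ccccc2/C1=C\C(=O)c1c[nH]c2ccccc12` gives 860 nM and compound 2 `O=C1Nc2ccc(F)cc2/C1=C\C(=O)c1ccc[nH]1` gives 1380 nM as its reading, so these two values lie within the usual scatter of each other. Compound 3 `O=C1Nc2ccc(F)cc2/C1=C\C(=O)c1cccs1` carries thiophen-2-yl in place of the 1H-pyrrol-2-yl of compound 2 on a carbonyl carbon (thiophen-2-yl in place of 1H-pyrrol-2-yl on a carbonyl carbon) and is otherwise the same. Among the compounds with values here, no measured step yet shows what this swap does. The expected change is small: a 1.4-fold lower number from compound 2 to compound 3 (0.14 log units; within the scatter) would stay within the scatter. For compound 3 the estimated value is 1000 nM with an expected range from 350 nM to 3000 nM as the likely span.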

Compound 3, half-maximal inhibitory concentration: 1840 nM
Compound 3: the middle estimate sits 1.8-fold (0.26 log units) below what was measured, within the range that was stated.
By their numbers in this assay, from the lowest: compounds 1, 2 and 3 (each within the scatter of the next, the first and the last beyond it).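

In this assay the swap gives a 1.3-fold higher number from compound 2 to compound 3 (0.12 log units; within the scatter) and so stays within the scatter, which means thiophen-2-yl and 1H-pyrrol-2-yl on this carbonyl carbon cannot be told apart by this reading. The hydrogen-bond donor of 1H-pyrrol-2-yl is absent from thiophen-2-yl, yet this pair shows no difference beyond the scatter. No independent measurement is available to explain this result.

From the compounds shown here alone, whether phenyl or furan-2-yl on this carbonyl carbon would give a clearly different number remains open. So does whether an amine-bearing ring would.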